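The compounds below may be only part of what the source reports. "The series", "measured", "known", "first", "only" and "open" are said of these compounds alone.

Three compounds have so far been measured in a functional assay on HepG2 cells (Homo sapiens) for inhibition, read by CCK-8 assay, with a stated time of 48 h; a lower number here means a stronger inhibitor, a higher number a weaker inhibitor:

compound 1, `Fc1ccc(C2=NN(C3=NC(c4ccccc4)CS3)C(c3cccc4ccccc34)C2)cc1`, giving 23200 nM;
compound 2, `O=C1CSC(N2N=C(c3ccc(Br)cc3)CC2c2cccc3ccccc23)=N1`, giving 13400 nM;
compound 3, `Cc1ccc(C2=NN(C3=NC(c4ccccc4)CS3)C(c3cccc4ccccc34)C2)cc1C`, giving 7250 nM.

Within this set compound 2 stands second highest of the three numbers. Its nearest neighbour is compound 1 and its furthest is compound 3, yet both of those gaps lie within the usual scatter of repeated measurements, so compound 2 cannot be placed above or below either of them with confidence. The one gap that does stand out is a 3.2-fold lower number from compound 1 to compound 3 (0.51 log units; beyond the scatter), a modest step produced by putting 3,4-dimethylphenyl in place of 4-fluorophenyl.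

Compound 4, `O=C1CSC(N2N=C(c3ccc(Cl)cc3)CC2c2cccc3ccccc23)=N1`, has not yet been measured. It differs from compound 2 in one place: chloro in place of bromo on an aromatic carbon. Among the compounds with values here, the change sits at the same position of the ring that was altered between compound 1 and compound 3, but those two compounds share a different core from compound 2, and no measured step swaps bromo for chloro anywhere in this set. Within the data shown here, with the change confined to a single group and no direct precedent, the number for compound 4 is expected to stay close to that of compound 2.

The step implied, a 1.0-fold higher number from compound 2 to compound 4 (0.02 log units; within the scatter), is expected to fall within the scatter. Compound 4 is therefore estimated at 14000 nM, with a range from 6000 nM to 32000 nM.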

Compound 4, half-maximal inhibitory concentration: 16500 nM
For compound 4 the middle estimate is 1.2-fold (0.07 log units) below the measured one, within the range that was stated.
By their numbers in this assay, from the lowest: compounds 3, 2, 4 and 1 (each within the scatter of the next, the first and the last beyond it).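

In this assay, putting chloro in place of bromo on the 4-bromophenyl group gives a 1.2-fold higher number from compound 2 to compound 4 (0.09 log units; within the scatter), so the two halogens cannot be told apart at this position on the core of compound 2. Within the data shown here, the step seen earlier, a 3.2-fold lower number from compound 1 to compound 3 (0.51 log units; beyond the scatter), came from a different exchange on a different core, whereas this pair is the first to isolate a swap of one halogen for another, with everything else in the molecule held the same. No measured property of either group is available to account for this result.

From the compounds shown here alone, whether this position tolerates larger departures from a halogen stays open, since a single close swap cannot show what an amine or a carboxylic acid at the same place would do to the number. Going by these compounds, it also remains open whether bromo and chloro would again be indistinguishable on the core of compound 1, which shares this aromatic ring but differs in the ring system attached to it, so the present result applies only to the core of compound 2.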